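Pyrrolidin-1-yl to piperidin-1-yl: compound 1 to compound 4

A few compounds are considered here, and "the series" means these few. Any claim that something is new, unique, unknown or untested is made for them only; others in the source may bear on it.

Measured so far:
compound 1, `COc1cc(OC)c(C(=O)c2ccccc2F)c(O)c1CN1CCCC1`, gives 15%
compound 2, `COc1cc(OC)c(C(=O)c2cccc(Cl)c2)c(O)c1CN1CCCC1`, gives 41%
compound 3, `COc1cc(OC)c(C(=O)c2cccc(F)c2)c(O)c1CN1CCCC1`, gives 34%

In a functional assay on THP-1 cells (Homo sapiens) for inhibition, read by ELISA, with stated times of 30 min and 24 h, tested at 1 uM (a higher number here means a stronger effect of the compound at the concentration tested, a lower number a weaker effect), compound 1 stands lowest of the three numbers, both other compounds lying beyond the scatter from it. The two steps away from compound 1 each change the aryl on the carbonyl carbon: a number 26 percentage points higher from compound 1 to compound 2 (beyond the scatter) and a number 19 percentage points higher from compound 1 to compound 3 (beyond the scatter). Between the two meta-substituted compounds the step is a number 7 percentage points lower from compound 2 to compound 3 (within the scatter), so the halogen swap itself makes no readable difference.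

Compound 4, `COc1cc(OC)c(C(=O)c2ccccc2F)c(O)c1CN1CCCCC1`, keeps the 2-fluorophenyl of compound 1 and changes only the amine: piperidin-1-yl in place of pyrrolidin-1-yl on a saturated chain carbon bound to an aromatic carbon. Within the data shown here, no measured step touches this part of the molecule; in all three measured compounds the (pyrrolidin-1-yl)methyl group is held constant while the aryl varies. The measured steps therefore give no guidance on direction or size for this change, and with nothing to point either way the working expectation is no step beyond the scatter.

Compound 4 is accordingly estimated at 16% in this assay, with a range of 2% to 34%, which would mean an expected step of a number 1 percentage points higher from compound 1 to compound 4 (within the scatter).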

Compound 4, a percentage reported as activity, at one concentration (the size of the read-out at that concentration, not a potency): 18%
Beside the measured number, compound 4's estimate is 2 percentage points below it; measured number inside the range.
By their numbers in this assay, from the lowest: compounds 1 and 4 (each within the scatter of the next); then compounds 3 and 2 (each within the scatter of the next).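

In this assay, the first change shown at the amine, on a saturated chain carbon bound to an aromatic carbon, gives a number 3 percentage points higher from compound 1 to compound 4 (within the scatter) and so leaves the reading unchanged within the usual scatter. With 2-fluorophenyl held on the carbonyl carbon, the six-membered piperidin-1-yl and the five-membered pyrrolidin-1-yl therefore read alike, whereas both aryl changes from compound 1 give steps beyond the scatter. No measurement at hand offers an explanation for this equivalence of the two rings.

Among these compounds, the amine change is seen only with 2-fluorophenyl on the carbonyl carbon, so it remains open whether piperidin-1-yl would also read like pyrrolidin-1-yl with the 3-chlorophenyl of compound 2 or the 3-fluorophenyl of compound 3. Also open, on these data alone, is whether the reading would hold with a ring carrying a second hetero atom, such as morpholin-4-yl or 4-methylpiperazin-1-yl, or with an open-chain amine such as dimethylamino in the same place.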